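Removing a chloro group from a lipophilic amide

The source may hold more compounds than are shown below. What is called first, only, known or untested is meant among the compounds shown, and "the series" means these compounds.

Compound 1, with structure `CCOc1ccccc1-c1ccc(-c2nc3cncc(Cl)c3c(N[C@H](CC)C(N)=O)c2C#N)cc1`, was measured in a physicochemical assay for lipophilicity, read by HPLC, at pH 7.5; a lower number here means a more polar compound, a higher number a more lipophilic compound. In this assay compound 1 gives 3.7. A second compound, compound 2 with structure `CCCCC(Nc1c(C#N)c(-c2ccc(-c3ccccc3OCC)cc2)nc2cnccc12)C(N)=O`, was measured alongside it; in this assay compound 2 gives 3.6. The two values differ by less than the scatter of the method, so neither compound can be called the more lipophilic of the pair.

Compound 3, with structure `CCOc1ccccc1-c1ccc(-c2nc3cnccc3c(N[C@H](CC)C(N)=O)c2C#N)cc1`, has not yet been measured. It differs from compound 1 in one place: hydrogen in place of chloro on an aromatic carbon. Chloro is a typical lipophilic substituent, and the change leaves every other part of the shared core untouched, so the comparison to compound 1 is clean.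

For the measured compounds named here, no measured pair in this set isolates this kind of change, so the size of the step rests on general experience with chloro-to-hydrogen swaps. The expected step of a number 0.60 log units lower from compound 1 to compound 3 (beyond the scatter) is a moderate drop, larger than the scatter. Compound 3 is therefore estimated to give 3.1 in this assay, with a likely range from 2.7 to 3.5.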

Compound 3, distribution coefficient: 3
Beside the measured number, compound 3's estimate is 0.10 log units above it; the measured number falls inside the stated range.
By their numbers in this assay, from the lowest: compound 3; then compounds 2 and 1 (each within the scatter of the next).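

In this assay the aromatic carbon that carries chloro proves responsive, since hydrogen in place of chloro gives a number 0.70 log units lower from compound 1 to compound 3 (beyond the scatter) in a single clean change that the first two compounds could not isolate. Compound 3 also gives compound 2 a partner that differs in one place, and 1-carbamoylpropyl in place of 1-carbamoylpentyl on the nitrogen gives a number 0.60 log units lower from compound 2 to compound 3 (beyond the scatter) as a second step beyond the scatter, so the closeness of the first two values, which come from compounds differing in two places, did not mean that either place leaves the number unmoved. No measurement shown here explains why either step has the size it has.

Going by these compounds, whether the chloro step keeps its size with 1-carbamoylpentyl on the nitrogen remains open, since only the 1-carbamoylpropyl compounds isolate that change. It is also unknown how other groups on the same aromatic carbon, such as fluoro, methoxy or an amine, or a side chain of intermediate length such as 1-carbamoylbutyl, would fall relative to these values.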